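This account rests on a few compounds, and the source may have more. Where it says the series, first, only, none or still open, it means among the compounds named here.

Measured compounds:
compound 1, `Cc1ccc(NC(=S)NC(=O)c2ccc(OCc3ccccc3)cc2)cc1-c1nc2ccccc2[nH]1`, in a functional assay on MGC-803 cells (Homo sapiens) for inhibition, read by MTT assay, with a stated time of 48 h (a higher number here means a weaker inhibitor, a lower number a stronger inhibitor), gives 60700 nM
compound 2, `Cc1ccc(NC(=S)NC(=O)c2ccc(OCc3cccc(Cl)c3)cc2)cc1-c1nc2ccccc2[nH]1`, in this assay gives 51300 nM

Among the measured compounds shown here, compound 2 holds the lower of the two numbers so far, but its only neighbour is compound 1, and the step of a 1.2-fold lower number from compound 1 to compound 2 (0.07 log units; within the scatter) lies within the scatter, so the two compounds cannot be ranked against each other.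

Compound 3, `Cc1ccc(NC(=S)NC(=O)c2ccc(OCc3ccc(C(F)(F)F)cc3)cc2)cc1-c1nc2ccccc2[nH]1`, is not yet measured. It differs from compound 2 by 4-(trifluoromethyl)phenyl in place of 3-chlorophenyl on a saturated chain carbon bound to an oxygen on an aromatic ring. For the measured compounds named here, the one measured step that touches this part of the structure is a 1.2-fold lower number from compound 1 to compound 2 (0.07 log units; within the scatter), a substituent change on the same ring that left the number within the scatter. Nothing measured separates one substituent on this ring from another, so no step beyond the scatter is expected in this assay; the step expected is a 1.0-fold lower number from compound 2 to compound 3 (0.01 log units; within the scatter). For compound 3 the estimate is 50000 nM, with a range from 22000 nM to 110000 nM.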

Compound 3, half-maximal inhibitory concentration: 6500 nM
Estimate against measurement, compound 3: 7.7-fold (0.89 log units) above; the whole stated range lies above it.
By their numbers in this assay, from the lowest: compound 3; then compounds 2 and 1 (each within the scatter of the next).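

In this assay the group on the saturated chain carbon bound to an oxygen on an aromatic ring is no longer without visible effect: 4-(trifluoromethyl)phenyl in place of 3-chlorophenyl gives a 7.9-fold lower number from compound 2 to compound 3 (0.90 log units; beyond the scatter), and trifluoromethyl in place of hydrogen gives a 9.3-fold lower number from compound 1 to compound 3 (0.97 log units; beyond the scatter). Compound 3 is therefore the strongest inhibitor of the three, while compound 1 and compound 2 remain unranked, so the substituent on this ring can matter, though chloro in compound 2 did not show it. Nothing available accounts for the size of these steps.

Chloro and trifluoromethyl stand at different ring positions in compound 2 and compound 3, so the compounds shown do not separate the identity of the group from its place on the ring. Going by these compounds, how an amine or a carboxylic acid on this ring would read in this assay also remains open.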